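Removing the acyl group from a tetrahydroquinoline amide

A few compounds are considered here, and "the series" means these few. Any claim that something is new, unique, unknown or untested is made for them only; others in the source may bear on it.

Compound 1 `O=C(Nc1cc(C(F)(F)F)cc(C(F)(F)F)c1)C1CCc2ccccc2N1C(=O)c1ccc(Cl)cc1`: 2570 nM
Compound 2 `CCCC(=O)N1c2ccccc2CCC1C(=O)Nc1ccccc1C(F)(F)F`: > 70000 nM
Compound 3 `O=C(Nc1ccc(O)cc1)C1CCc2ccccc2N1`: > 100000 nM

In a functional assay on ACHN cells (Homo sapiens) for cytotoxicity, read by sulforhodamine B assay, with a stated time of 72 h (on this read-out higher numbers stand for weaker inhibition of growth and lower numbers for stronger inhibition of growth), compound 1 gives 2570 nM, the only numeric result among the three. For compound 2 only a limit is reported, > 70000 nM. For compound 3 the result is likewise a limit, > 100000 nM. Compound 4 `O=C(Nc1cc(C(F)(F)F)cc(C(F)(F)F)c1)C1CCc2ccccc2N1` is not yet measured; it differs from compound 1 by hydrogen in place of (4-chlorophenyl)carbonyl on a nitrogen on an aromatic ring in a ring. Compound 3 also carries hydrogen on that ring nitrogen and reaches only the limit > 100000 nM in this assay. A large step toward weaker growth inhibition is therefore expected. Compound 4 is estimated at 40000 nM (range 8000 nM to 200000 nM), a step of a 16-fold higher number from compound 1 to compound 4 (1.19 log units; beyond the scatter), and the assay may report only a limit.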

Compound 4, concentration for 50% growth inhibition: 8190 nM
Estimate against measurement, compound 4: 4.9-fold (0.69 log units) above, within the range that was stated.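

In this assay, the (4-chlorophenyl)carbonyl group on the ring nitrogen proves helpful but not essential: replacing it with hydrogen gives a 3.2-fold higher number from compound 1 to compound 4 (0.50 log units; beyond the scatter) and only a modest loss of growth inhibition. Compound 4 still gives a numeric result rather than a limit, so growth inhibition persists with hydrogen on this nitrogen. Nothing measured here explains the size of this step.

The compounds shown leave open how an acetyl group or a methyl group on this nitrogen would compare with compound 1 and compound 4.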